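A Single Substituted Ring Returns After a Fused One

This account rests on a few compounds, and the source may have more. Where it says the series, first, only, none or still open, it means among the compounds named here.

Compound 1 `c1ccc(-c2cn3ccnc3c(-c3ccc4ncn(C5CCCCC5)c4c3)n2)cc1` and compound 2 `c1ccc2c(-c3cn4ccnc4c(-c4ccc5ncn(C6CCCCC6)c5c4)n3)cccc2c1` share one core and differ only in the group carried on a single aromatic carbon. In a functional assay on UO-31 cells (Homo sapiens) for inhibition, read by sulforhodamine B assay, with a stated time of 48 h, tested at 10 uM (on this read-out higher numbers stand for more inhibition at the one concentration tested (going by the name of the read-out) and lower numbers for less inhibition), compound 1 gives 55.2%, and compound 2 gives 23%. Among the measured compounds shown here, the one measured step is a number 32.2 percentage points lower from compound 1 to compound 2 (beyond the scatter). On these two numbers compound 2 stands lowest; its nearest neighbour is compound 1, which lies beyond the scatter above it.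

Compound 3 `COc1ccccc1-c1cn2ccnc2c(-c2ccc3ncn(C4CCCCC4)c3c2)n1` has not yet been measured. Its change from compound 2 is 2-methoxyphenyl in place of naphthalen-1-yl on an aromatic carbon, which returns to one six-membered ring of carbon only, now bearing a methoxy group, where compound 2 carries two fused rings. For the measured compounds named here, the only step that bears on this is the one from compound 1 to compound 2, where the move from phenyl to naphthalen-1-yl gave a large loss. Compound 3 is therefore expected to recover most of that loss, with an estimated step of a number 22 percentage points higher from compound 2 to compound 3 (beyond the scatter). Compound 3 is expected to give about 45%, in a range from 20% to 70%.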

Compound 3, a percentage reported as inhibition, at one concentration (the size of the read-out at that concentration, not a potency): 24%
The estimate for compound 3 lay 21 percentage points above the measured number, and the stated range covers the measured number.
By their numbers in this assay, from the lowest: compounds 2 and 3 (each within the scatter of the next); then compound 1.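

In this assay, the step is a number 1 percentage points higher from compound 2 to compound 3 (within the scatter) and so shows that going back from the two fused rings of naphthalen-1-yl to one ring does not by itself bring back the number of compound 1 when that ring carries a methoxy group. Set against the plain phenyl, the result reads as a number 31.2 percentage points lower from compound 1 to compound 3 (beyond the scatter) and this is the first view of a substituent on the single ring at this position, where methoxy in place of hydrogen is enough to leave the number well short of compound 1. At this position, then, two quite different changes to the phenyl of compound 1, the fused second ring and the methoxy group, end within the scatter of each other, so the large drop is not tied to the fused ring alone.

The compounds shown leave open whether the drop belongs to methoxy in particular or would also follow a fluorine atom, a methyl group or an amine on the same ring, and whether any such group could match or pass the plain phenyl. Nothing given here bears on what lies behind these numbers.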